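Removing the Bromine from a Triazole-Linked Phenyl Ring

The source may hold more compounds than are shown below. What is called first, only, known or untested is meant among the compounds shown, and "the series" means these compounds.

Three compounds have been measured in a functional assay on MCF7 cells (Homo sapiens) for cytotoxicity, read by MTT assay, with a stated time of 4 days; a lower number here means a stronger inhibitor, a higher number a weaker inhibitor:

Compound 1, `C=C1C(=O)[C@]23C[C@@]1(O)CC[C@H]2c1ccc(O)c(C)c1[C@@H]3Cn1cc(-c2ccccn2)nn1`, gives 2240 nM.
Compound 2, `C=C1C[C@]23C[C@@]1(O)CC[C@@H]2c1cccc(C)c1[C@@H]3Cn1cc(-c2ccc(OC)cc2)nn1`, gives > 20000 nM, which is a limit of the assay.
Compound 3, `C=C1C[C@]23C[C@@]1(O)CC[C@@H]2c1cccc(C)c1[C@@H]3Cn1cc(-c2ccc(Br)cc2)nn1`, gives > 20000 nM, which is a limit of the assay.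

Compound 3 therefore stands at the limit of > 20000 nM in this assay, at which 2 of the 3 values shown sit, and compound 2 stands there as well. Among the measured compounds shown here, the only step among the measured compounds that differs in a single place is a step that the two limits leave unreadable from compound 2 to compound 3; with both ends at the limit, its size cannot be read. For the measured compounds named here, compound 1 carries a different core and a different group on the triazole, so no single-point step connects it to compound 3; it is simply the one compound in this set whose value is a number rather than a limit.

Compound 4, `C=C1C[C@]23C[C@@]1(O)CC[C@@H]2c1cccc(C)c1[C@@H]3Cn1cc(-c2ccccc2)nn1`, differs from compound 3 by hydrogen in place of bromo on an aromatic carbon. Going by the values given here, no measured step bears directly on this change, and the one step that comes closest is unreadable. That step gives no indication that a change on this ring brings the value back into the readable range. Compound 4 is therefore expected to remain at or near the limit, the estimated step being a step that the limit leaves unreadable from compound 3 to compound 4. The estimate for compound 4 in this assay is 25000 nM, with a range from 8000 nM to 80000 nM.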

Compound 4, half-maximal inhibitory concentration: > 20000 nM
Compound 4 gave a limit, no number; the forecaster's own chance of this, stated with the estimate: 70%; the middle value does not contradict the limit.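

In this assay compound 4 gives > 20000 nM, which is a limit of the assay and not a number. It joins compound 2 and compound 3 there: the limit of > 20000 nM in this assay, at which 3 of the 4 values shown sit. No step among these three compounds can be read. The compounds shown leave open whether any group on this phenyl ring changes the value at all.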